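Exchanging the side chain once more: compound 2 to compound 3

A few compounds are considered here, and "the series" means these few. Any claim that something is new, unique, unknown or untested is made for them only; others in the source may bear on it.

Compound 2 `C[C@@H](O)[C@H](NC(=O)CN(c1ncnc2c1ncn2C1CCCCO1)C1CC1)C(=O)OCc1ccccc1` was examined in a functional assay on the whole organism (Tail, strain ICR) with Mus musculus as the target, in the tail flick test, with a stated time of 120 min, at a dose of 25 umol/kg by the oral route (on this read-out higher numbers stand for a stronger effect at the one dose given and lower numbers for a weaker effect), where compound 2 gives 10.9%. Within the data shown here, of the two numbers in hand this is the smaller, yet the gap to its only neighbour lies within the scatter: compound 1 `O=C(CN(c1ncnc2c1ncn2C1CCCCO1)C1CC1)N[C@@H](CCC(=O)OCc1ccccc1)C(=O)OCc1ccccc1` gives 20.7% in this assay, and the step was a number 9.8 percentage points lower from compound 1 to compound 2 (within the scatter). Compound 3 `NC(=O)C[C@H](NC(=O)CN(c1ncnc2c1ncn2C1CCCCO1)C1CC1)C(=O)OCc1ccccc1` has not been measured. It differs from compound 2 in one place: carbamoylmethyl in place of 1-hydroxyethyl on a saturated chain carbon bound to an amide-type nitrogen and a carbonyl carbon. Among the measured compounds shown here, the only measured step that bears on this change is the exchange at the same place that led from compound 1 to compound 2, and that step stayed within the scatter. Nothing in hand therefore points to a step beyond the scatter in this assay, and the estimated step is a number 3.1 percentage points higher from compound 2 to compound 3 (within the scatter). Compound 3 is accordingly expected to give about 14%, within a range from 0% to 32%.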

Compound 3, a percentage reported as activity, at one dose (the size of the read-out at that dose, not a potency): 29.2%
Compound 3: the middle estimate sits 15.2 percentage points below what was measured, and the stated range covers the measured number.
By their numbers in this assay, from the lowest: compounds 2, 1 and 3 (each within the scatter of the next, the first and the last beyond it).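

Carbamoylmethyl in place of 1-hydroxyethyl, on a saturated chain carbon bound to an amide-type nitrogen and a carbonyl carbon, gives the first step beyond the scatter in this assay (a number 18.3 percentage points higher from compound 2 to compound 3 (beyond the scatter)), so the group at this place can shift the read-out, which the earlier step within the scatter did not show. The comparison with compound 1, carbamoyl in place of (benzyloxycarbonyl)methyl two bonds along the chain, stays within the scatter (a number 8.5 percentage points higher from compound 1 to compound 3 (within the scatter)), so only compound 2 and compound 3 stand apart, and compound 1 is separated from neither. Nothing in hand gives a measured explanation for this step.

As far as these compounds go, it stays open how a carboxylic acid, an amine or a longer chain ending in carbamoyl would read at this place. The compounds shown also leave open whether the step between compound 2 and compound 3 holds at other doses or times.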